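Aryl for benzyl at the ring amine nitrogen: compound 4

The source may hold more compounds than are shown below. What is called first, only, known or untested is meant among the compounds shown, and "the series" means these compounds.

Among the measured compounds shown here, compound 3 `Nc1ccccc1NC(=O)c1ccc(CSC(=S)N2CCN(Cc3ccncc3)CC2)cc1` gives 79.3% in a functional assay on MGC-803 cells (Homo sapiens) for antiproliferative activity, read by CCK-8 assay, with a stated time of 72 h, tested at 8 uM (a higher number here means a stronger effect of the compound at the concentration tested, a lower number a weaker effect), the lowest of the three numbers so far, though within the scatter of compound 2 `CCN(Cc1ccncc1)C(=S)SCc1ccc(C(=O)Nc2ccccc2N)cc1` at 85.2% and of compound 1 `CC1CCCCN1C(=S)SCc1ccc(C(=O)Nc2ccccc2N)cc1` at 86.9%. Compound 4 `Nc1ccccc1NC(=O)c1ccc(CSC(=S)N2CCN(c3cccnc3)CC2)cc1` carries pyridin-3-yl in place of (pyridin-4-yl)methyl on an amine nitrogen in a ring. For the measured compounds named here, the only measured step, a number 1.7 percentage points lower from compound 1 to compound 2 (within the scatter), concerns a different site on the thiocarbonyl carbon and changes little. Going by the values given here, no measured step exchanges a pyridinylmethyl for a pyridinyl group, so nothing bears directly on this change. With all three values close together, no step beyond the scatter is expected, and the step of a number 1.3 percentage points lower from compound 3 to compound 4 (within the scatter) is estimated as essentially flat. Compound 4 is expected near 78%, within 65% to 88%.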

Compound 4, a percentage reported as inhibition, at one concentration (the size of the read-out at that concentration, not a potency): 76.9%
Beside the measured number, compound 4's estimate is 1.1 percentage points above it; the measured number falls inside the stated range.
By their numbers in this assay, from the lowest: compounds 4, 3, 2 and 1 (each within the scatter of the next).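

On the amine nitrogen in the ring, the step of a number 2.4 percentage points lower from compound 3 to compound 4 (within the scatter) in this assay shows that pyridin-3-yl in place of (pyridin-4-yl)methyl leaves the read-out without a change that can be told from the scatter. This first step at this position alters the carbon link and the pyridine attachment together, so neither can be read alone. Nothing at hand gives a cause for this flat step.

On these data alone, whether a phenyl ring or a plain alkyl chain on the same nitrogen would hold the read-out stays open. As far as these compounds go, with a single tested concentration, any potency gap within this group also stays open.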